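Side-chain exchange from compound 3 to compound 4

The source may hold more compounds than are shown below. What is called first, only, known or untested is meant among the compounds shown, and "the series" means these compounds.

In a functional assay on RS4-11 cells (Homo sapiens) for inhibition, read by CCK-8 assay, with a stated time of 72 h (a higher number here means a weaker inhibitor, a lower number a stronger inhibitor), compound 3 `CN1CCC(CNc2ccc(S(=O)(=O)NC(=O)c3ccc(N4CCN(CC5=C(c6ccc(C(F)(F)F)cc6)CC(C)(C)CC5)CC4)cc3Oc3cnc4[nH]ccc4c3)cc2[N+](=O)[O-])C1` gives 8.3 nM, the lowest of the three numbers and beyond the scatter from the other two. Compound 1 `CC1(C)CCC(CN2CCN(c3ccc(C(=O)NS(=O)(=O)c4ccc(NCC5CCOCC5)c([N+](=O)[O-])c4)c(Oc4cnc5[nH]ccc5c4)c3)CC2)=C(c2cccc(C(F)(F)F)c2)C1` gives 63 nM, and compound 2 `CC1(C)CCC(CN2CCN(c3ccc(C(=O)NS(=O)(=O)c4ccc(NCC5CCOCC5)c([N+](=O)[O-])c4)c(Oc4cnc5[nH]ccc5c4)c3)CC2)=C(c2ccc(C(F)(F)F)c(Cl)c2)C1` gives 81 nM.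

Compound 4 `CC1(C)CCC(CN2CCN(c3ccc(C(=O)NS(=O)(=O)c4ccc(OCC5CCCOC5)c([N+](=O)[O-])c4)c(Oc4cnc5[nH]ccc5c4)c3)CC2)=C(c2ccc(C(F)(F)F)cc2)C1` departs from compound 3 at one site: a group of 8 heavy atoms (6 carbon, 2 oxygen; one six-membered non-aromatic ring with 1 hetero atom) in place of a group of 8 heavy atoms (6 carbon, 2 nitrogen; one five-membered non-aromatic ring with 1 hetero atom), on an aromatic carbon. The ((1-methylpyrrolidin-3-yl)methyl)amino group leaves an aromatic carbon that is ortho to a nitro group and para to a large group.

Going by the values given here, the only measured single-site step is a 1.3-fold higher number from compound 1 to compound 2 (0.11 log units; within the scatter). It lies within the scatter and concerns the aryl group on a double-bonded ring carbon, so it says nothing directly about this exchange. Among the compounds with values here, no measured pair isolates the change at the site in question. The nearest evidence is indirect: compound 1 at 63 nM and compound 2 at 81 nM also carry a six-membered non-aromatic ring with 1 hetero atom in this side chain, although both also differ from compound 3 in the aryl group and neither matches the entering group.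

A move towards weaker inhibition in this assay is therefore expected, with the expected step being a 3.6-fold higher number from compound 3 to compound 4 (0.56 log units; beyond the scatter). Compound 4 is estimated at 30 nM, with an expected range of 8 nM to 120 nM.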

Compound 4, half-maximal inhibitory concentration: 12 nM
Beside the measured number, compound 4's estimate is 2.5-fold (0.40 log units) above it; the measured number falls inside the stated range.
By their numbers in this assay, from the lowest: compounds 3 and 4 (each within the scatter of the next); then compounds 1 and 2 (each within the scatter of the next).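

In this assay, going by these compounds alone, the exchange on the aromatic carbon ortho to a nitro group and para to a large group gives the first single-site reading at this position (a 1.4-fold higher number from compound 3 to compound 4 (0.16 log units; within the scatter)); compound 1 and compound 2 differ from compound 3 in more than one place and could not isolate it. The ((1-methylpyrrolidin-3-yl)methyl)amino group can therefore give way to a group with a six-membered non-aromatic ring, with 2 oxygen in place of 2 nitrogen and 0 hydrogen-bond donors in place of 1, without a shift beyond the scatter. Nothing available explains this outcome.

Ring size, hetero atoms and donor count all change in this one step, so their separate contributions remain unresolved, as does whether the same tolerance holds with the other aryl groups in the series. Also open, from the compounds shown here alone, is how this position responds to groups of a different kind, such as a carboxylic acid, a primary amine or a longer open alkyl chain.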